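Acetamido to propanoylamino: extending the amide chain

The compounds below may be only part of what the source reports. "The series", "measured", "known", "first", "only" and "open" are said of these compounds alone.

Measured so far in an assay on cells for inhibition of cytochrome P450 11B2, mitochondrial (Homo sapiens), read by HTRF; on this read-out higher numbers stand for weaker inhibition and lower numbers for stronger inhibition:
compound 1 `CCS(=O)(=O)N1CCC(c2cncc(N3C(=O)c4ccc(Cl)cc4C3(C)C)c2)CC1` gives 3 nM
compound 2 `CC(=O)N[C@@H]1CCCc2c1cncc2N1C(=O)c2ccc(Cl)cc2[C@H]1C` gives 130 nM
compound 3 `CC(=O)N[C@@H]1CCCc2c1cncc2N1C(=O)c2ccc(Cl)cc2[C@H]1C1CC1` gives 100 nM

Compound 2 carries the highest of the three numbers. Its nearest neighbour is compound 3, reached by a 1.3-fold lower number from compound 2 to compound 3 (0.11 log units; within the scatter), so the two cannot be told apart on this read-out. Compound 1 sits furthest from compound 2, and that gap lies beyond the scatter.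

Compound 4 `CCC(=O)N[C@@H]1CCCc2c1cncc2N1C(=O)c2ccc(Cl)cc2[C@H]1C` is the next member of the series, not yet measured. It differs from compound 2 by methyl in place of hydrogen on a saturated chain carbon bound to a carbonyl carbon. Among the measured compounds shown here, no measured pair shows this same change. For the measured compounds named here, the only step available, a 1.3-fold lower number from compound 2 to compound 3 (0.11 log units; within the scatter), alters a different position and did not move the number beyond the scatter. The two nearest analogues, compound 2 and compound 3, therefore give no indication that small additions of this kind shift the series, and nothing here argues for a step in either direction. The expectation for compound 4 is accordingly no step beyond the scatter, no change at the digits printed from compound 2 to compound 4 (within the scatter). On that basis compound 4 is estimated at 130 nM in this assay, with a range from 50 nM to 350 nM.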

Compound 4, half-maximal inhibitory concentration: 66 nM
Compound 4: the middle estimate sits 2.0-fold (0.29 log units) above what was measured, and the stated range covers the measured number.
By their numbers in this assay, from the lowest: compound 1; then compounds 4, 3 and 2 (each within the scatter of the next).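

In this assay, among the compounds shown here, the change from acetamido to propanoylamino gives a 2.0-fold lower number from compound 2 to compound 4 (0.29 log units; within the scatter), the first reading on the amide chain itself, and it shows that this position accepts one added methyl on the saturated chain carbon bound to the carbonyl carbon without a step beyond the scatter. Together with a 1.3-fold lower number from compound 2 to compound 3 (0.11 log units; within the scatter), which alters a different position, this means that two separate small additions to compound 2 have now been read, and neither separates from compound 2 on this read-out. No measurement bearing on the reason for the size of this step is available.

Still open, from the compounds shown here alone, is how the number responds to larger changes at the amide chain, such as a butanoyl group, a cyclopropanecarbonyl group, or a chain ending in an amine or a carboxylic acid, since a single added methyl says little about how far the chain can be extended. Also open, going by these compounds, is whether propanoylamino behaves in the same way when cyclopropyl replaces methyl on the saturated ring carbon, as it does in compound 3.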